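A Sulfonyl Swap at the Clearance Limit

This account rests on a few compounds, and the source may have more. Where it says the series, first, only, none or still open, it means among the compounds named here.

In an ADME assay (liver) for metabolic stability, with Liver microsome (Homo sapiens) as the target, read by LC-MS, using microsomes and NADPH, with a stated time of 5 min, at 37 degrees C (a lower number here means slower removal, a higher number faster removal of the compound), compound 1 `CCn1c([C@@H](C)NS(=O)(=O)c2cccc(Cl)c2)nc2ccc(C(F)(F)F)cc21` reports only a limit, > 100 mL.min-1.g-1. Compound 3 `CCn1c([C@@H](C)NS(=O)(=O)c2cnn(C(C)C)c2C)nc2ccc(C(F)(F)F)cc21` also reports only a limit, > 100 mL.min-1.g-1. Compound 2 `CCn1cc(S(=O)(=O)N[C@H](C)c2nc3ccc(C(F)(F)F)cc3n2CC)cn1` gives a true number, 95 mL.min-1.g-1. Compound 3 therefore stands at the limit of > 100 mL.min-1.g-1 in this assay, at which 2 of the 3 values shown sit. Compound 4 `CCn1c([C@@H](C)NS(=O)(=O)c2cn(C)c(C)n2)nc2ccc(C(F)(F)F)cc21` carries 1,2-dimethyl-1H-imidazol-4-yl in place of 1-isopropyl-5-methyl-1H-pyrazol-4-yl on a sulfonyl sulfur. Among the measured compounds shown here, the steps that bear on this change give only floors or nothing readable: an at least 1.0-fold lower number from compound 1 to compound 2 (0.02 log units; that floor lies within the scatter), an at least 1.0-fold higher number from compound 2 to compound 3 (0.02 log units; that floor lies within the scatter) and a step that the two limits leave unreadable from compound 1 to compound 3. Only compound 2, at 95 mL.min-1.g-1, shows a true number, so the expected direction rests on that single value. A lower number is expected in this assay, an at least 1.4-fold lower number from compound 3 to compound 4 (0.15 log units; that floor lies within the scatter). For compound 4 the estimated value is 70 mL.min-1.g-1, with an expected range from 30 mL.min-1.g-1 to 130 mL.min-1.g-1.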

Compound 4, intrinsic clearance in microsomes: 43 mL.min-1.g-1
For compound 4 the middle estimate is 1.6-fold (0.21 log units) above the measured one; low and high end bracket the measured number.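

Among the compounds shown here, at this position on the sulfonyl sulfur, 1,2-dimethyl-1H-imidazol-4-yl gives the first change in this assay that can be read beyond the scatter: a 2.2-fold lower number from compound 2 to compound 4 (0.34 log units; beyond the scatter). Against the other two compounds the steps are only floors, an at least 2.3-fold lower number from compound 3 to compound 4 (0.36 log units; beyond the scatter) and an at least 2.3-fold lower number from compound 1 to compound 4 (0.36 log units; beyond the scatter). Compound 1 and compound 3 each report only a limit: the limit of > 100 mL.min-1.g-1 in this assay, at which 2 of the 4 values shown sit.

From the compounds shown here alone, how far compound 1 and compound 3 truly lie from compound 4 stays open. So does whether 1-methyl-1H-imidazol-4-yl on the sulfonyl sulfur would give the same lower number.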